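Indazolyl urea series: growth inhibition, compound 3 to compound 4

The source may hold more compounds than are shown below. What is called first, only, known or untested is meant among the compounds shown, and "the series" means these compounds.

Measured compounds:
compound 1 `O=C(Nc1ccccc1OC(F)(F)F)Nc1n[nH]c2ccccc12` with 12900 nM
compound 2 `O=C(Nc1ccc(Cc2ccccc2)cc1)Nc1nn(C(=O)Nc2ccc(Cc3ccccc3)cc2)c2ccccc12` with 18000 nM
compound 3 `Nc1nn(C(=O)Nc2ccc(Cc3ccccc3)cc2)c2ccccc12` with 14200 nM

In a functional assay on HOP-92 cells (Homo sapiens) for inhibition, read by sulforhodamine B assay, with a stated time of 48 h (a lower number here means a stronger inhibitor of growth, a higher number a weaker inhibitor of growth), the three measured compounds sit close together. Compound 3 gives 14200 nM, the second highest of the three numbers; its nearest neighbour is compound 1 at 12900 nM and its furthest is compound 2 at 18000 nM, and both gaps lie within the usual scatter, so no ordering among compound 1, compound 2 and compound 3 can be read from this assay.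

Compound 4 `CCCCOc1ccc(NC(=O)n2nc(N)c3ccccc32)cc1` is the next member to be measured. It differs from compound 3 in one place: butoxy in place of benzyl on an aromatic carbon. The change is butoxy in place of benzyl on an aromatic carbon, para to a large group, on the ring carried by the carbonyl-linked amine of compound 3; the shared core is unchanged.

Within the data shown here, no step between measured compounds bears on this exchange, and the three numbers available are all within scatter of one another, so no direction is indicated. The step from compound 3 to compound 4 is expected to be a 1.1-fold higher number from compound 3 to compound 4 (0.02 log units; within the scatter), that is, none beyond the scatter. Compound 4 is accordingly estimated at 15000 nM, with a range from 6000 nM to 40000 nM.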

Compound 4, concentration for 50% growth inhibition: 18600 nM
For compound 4 the middle estimate is 1.2-fold (0.09 log units) below the measured one; the measured number falls inside the stated range.
By their numbers in this assay, from the lowest: compounds 1, 3, 2 and 4 (each within the scatter of the next).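

Among these compounds, exchanging benzyl for butoxy on an aromatic carbon, para to a large group, gives in this assay a 1.3-fold higher number from compound 3 to compound 4 (0.12 log units; within the scatter) and so provides the first direct comparison at this place. A group with a six-membered aromatic ring and a hydrogen-bond-acceptor-free carbon linkage and a ringless group with a hydrogen-bond acceptor therefore cannot be told apart here, although the step does not show that the two are equivalent in any other setting. No measurement at hand accounts for this result.

As far as these compounds go, whether an amine, a carboxylic acid or a longer alkoxy chain at this place would give a step beyond the scatter remains open. From the compounds shown here alone, it is also open whether any change on this ring can move the series out of the narrow band its four numbers occupy.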